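The source may hold more compounds than are shown below. What is called first, only, known or untested is meant among the compounds shown, and "the series" means these compounds.

Measured compounds:
Compound 1 `CCOC(=O)C1=C(C)NC(=S)NC1c1ccc(O)cc1` gives > 250 ug/mL in a functional assay on HT-29 cells (Homo sapiens) for inhibition, read by sulforhodamine B assay, with a stated time of 48 h (a lower number here means a stronger inhibitor of growth, a higher number a weaker inhibitor of growth), and that figure is a limit of the assay rather than a number.
Compound 2 `CCOC(=O)C1=C(C)NC(=S)NC1c1ccc(O)c(O)c1` gives 33.7 ug/mL in this assay.
Compound 3 `CCOC(=O)C1=C(C)NC(=S)NC1c1cccc(OC)c1` gives 28.3 ug/mL in this assay.

Among the compounds with values here, compound 3 thus sits at the low end of the two numbers that exist, and its number and that of compound 2 lie within the usual scatter of each other; the only other value, that of compound 1, is a limit (the limit of > 250 ug/mL in this assay, at which 1 of the 3 values shown sits).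

Compound 4 `CCOC(=O)C1=C(C)NC(=S)NC1c1ccc(O)c(OC)c1` differs from compound 3 by hydroxy in place of hydrogen on an aromatic carbon. Within the data shown here, one measured step bears on this change: the same kind of addition, a hydroxy in place of hydrogen on an aromatic carbon, gave an at least 7.4-fold lower number from compound 1 to compound 2 (0.87 log units; beyond the scatter). That step started from a limit, so its true size is not known, and the ring in compound 3 already carries a methoxy group; the step from compound 3 to compound 4 is therefore expected to be smaller, a lowering of a 1.6-fold lower number from compound 3 to compound 4 (0.20 log units; within the scatter). Compound 4 is estimated at 18 ug/mL, with a range from 7 ug/mL to 50 ug/mL.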

Compound 4, concentration for 50% growth inhibition: 34.9 ug/mL
For compound 4 the middle estimate is 1.9-fold (0.29 log units) below the measured one; the range from low to high includes it.
By their numbers in this assay, from the lowest: compounds 3, 2 and 4 (each within the scatter of the next). At a limit, above all of these: compound 1.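

In this assay, hydroxy in place of hydrogen, set ortho to a methoxy group and para to a large group, gave a step within the scatter, a 1.2-fold higher number from compound 3 to compound 4 (0.09 log units; within the scatter), and methyl in place of hydrogen on an oxygen on the aromatic ring also stayed within it, a 1.0-fold higher number from compound 2 to compound 4 (0.02 log units; within the scatter). The same hydroxy change therefore does not carry over from one core to the other: the same change on two cores in this assay, an at least 7.4-fold lower number (0.87 log units; beyond the scatter) from compound 1 to compound 2 and a 1.2-fold higher number (0.09 log units; within the scatter) from compound 3 to compound 4, at least 9.1-fold (0.96 log units) apart, beyond the scatter of two such steps Only an at least 7.1-fold lower number from compound 1 to compound 4 (0.85 log units; beyond the scatter) lies beyond the scatter, and its starting value is a limit of the assay, not a number, which leaves its true size unknown.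

The compounds shown leave open whether a different group at this place, such as an amine or a carboxylic acid, would move the number beyond the scatter. They also leave open whether a longer chain, such as ethoxy in place of the methoxy group, would do so.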